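Trimming the Ether: Compound 4 Against Compound 1

This account rests on a few compounds, and the source may have more. Where it says the series, first, only, none or still open, it means among the compounds named here.

Compound 1, `COCCOc1cc2oc(=O)n(CCC(=O)O)c2cc1Cl`: 70.7%
Compound 2, `O=C(O)CCn1c(=O)oc2cc(OCC3CC3)c(Cl)cc21`: 96%
Compound 3, `C[C@@H](Oc1cc2oc(=O)n(CCC(=O)O)c2cc1Cl)c1ccc(Cl)cn1`: 99%

In an ADME assay on a cell-free system (plasma, Homo sapiens) for protein binding, compound 1 gives 70.7%, the highest unbound fraction of the three measured compounds. Compound 2 gives 96% and compound 3 gives 99%, both bound to a greater degree than compound 1. Compound 4, `CCOc1cc2oc(=O)n(CCC(=O)O)c2cc1Cl`, differs from compound 1 only in the chain on the aryl oxygen: hydrogen in place of methoxy on a saturated chain carbon, two bonds along the chain from an oxygen on an aromatic ring.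

Within the data shown here, one measured step touches the same chain: a 7.3-fold lower unbound fraction from compound 1 to compound 2 (0.86 log units; beyond the scatter), where the methoxymethyl gave way to a cyclopropyl and the compound became much more tightly bound. Compound 4 also loses the methoxy, but nothing enters in its place beyond a hydrogen, leaving an ethoxy chain that is shorter than the chain of compound 2. A shift toward a lower unbound fraction is therefore expected, though smaller than the step from compound 1 to compound 2. The expected step is a 2.0-fold lower unbound fraction from compound 1 to compound 4 (0.29 log units; within the scatter). Compound 4 is estimated at 85%, with a likely range from 72% to 93%.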

Compound 4, plasma protein binding: 95.8%
Beside the measured number, compound 4's estimate is 3.6-fold (0.55 log units) (unbound fraction) above it, and the stated range ends below it.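

In this assay, hydrogen in place of methoxy, on the saturated chain carbon two bonds along the chain from the oxygen on the aromatic ring, is a large change on its own: a 7.0-fold lower unbound fraction from compound 1 to compound 4 (0.84 log units; beyond the scatter) shows that trimming 2-methoxyethoxy to ethoxy is enough, with no ring entering. Methyl in place of cyclopropyl then gives a 1.1-fold higher unbound fraction from compound 2 to compound 4 (0.02 log units; within the scatter), so at this position the read-out does not tell the two chains apart, and the cyclopropyl of compound 2 shows no gain over the plain ethoxy. Only the 5-chloropyridin-2-yl group separates further, with a 4.2-fold higher unbound fraction from compound 3 to compound 4 (0.62 log units; beyond the scatter) running back from the most tightly bound compound.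

On these data alone, whether a hydroxyl or an amine at the end of the ethoxy chain, or a longer chain such as propoxy, would behave like methoxy or like hydrogen stays open. Nothing shown gives a reason for the size of these steps.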